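Arylamino for Piperidinyl on Two Related Cores

The source may report more compounds than this note shows. Statements on the series, on what has been measured and on what is new or still open speak of the compounds shown alone.

The measured compounds in brief:
compound 1 `O=C1C(N2CCCCC2)=CC(=O)c2c1nc1n2[C@H]2OC[C@@H](O)[C@H]2OC1` gives > 16000 nM in a functional assay on HeLa cells (Homo sapiens) for inhibition, read by sulforhodamine B assay; on this read-out lower numbers stand for stronger inhibition and higher numbers for weaker inhibition
compound 2 `COc1cccc(NC2=CC(=O)c3c(nc4n3[C@H]3OC[C@@H](O)[C@H]3OC4)C2=O)c1` gives > 8000 nM in this assay
compound 3 `O=C1C=C(N2CCCCC2)C(=O)c2c1nc1n2[C@H]2OC[C@@H](O)[C@H]2OC1` gives > 16000 nM in this assay

Each of these three values is a limit of this assay, not a number; for compound 1 the value > 16000 nM is such a limit. For compound 2 the value > 8000 nM is likewise a limit. For compound 3 the value > 16000 nM is a limit as well. Two of the three values sit at the limit of > 16000 nM in this assay, at which 2 of the 3 values shown sit, and one at the limit of > 8000 nM in this assay, at which 1 of the 3 values shown sits.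

The change from compound 1 to compound 2 is (3-methoxyphenyl)amino in place of piperidin-1-yl on a double-bonded ring carbon. Its step, a step that the two limits leave unreadable from compound 1 to compound 2, cannot be read, since both ends are limits. Compound 3 shares its atoms with compound 1 but joins them differently; the difference between the two cores is not broken down here.

Going by the values given here, compound 4 `COc1cccc(NC2=CC(=O)c3nc4n(c3C2=O)[C@H]2OC[C@@H](O)[C@H]2OC4)c1` arises from compound 3 by (3-methoxyphenyl)amino in place of piperidin-1-yl on a double-bonded ring carbon, the same change as the one from compound 1 to compound 2. Among the compounds with values here, the only earlier instance of this change, a step that the two limits leave unreadable from compound 1 to compound 2, runs between two limits. For compound 3 the measured value > 16000 nM is a limit. Resting on that unreadable step and on that limit, the expected step of a number no higher from compound 3 to compound 4 (the limit leaves the size open) is set near zero. Compound 4 is therefore expected to give about 16000 nM, within 4000 nM to 60000 nM, most likely again reported only as a limit.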

Compound 4, half-maximal inhibitory concentration: 4280 nM
Compound 4: middle estimate off by 3.7-fold (0.57 log units), on the high side; low and high end bracket the measured number.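

In this assay, putting (3-methoxyphenyl)amino in place of piperidin-1-yl on a double-bonded ring carbon gives an at least 3.7-fold lower number from compound 3 to compound 4 (0.57 log units; beyond the scatter), so on the core of compound 3 this change goes with stronger inhibition. On these data alone, the true size of the step stays open because compound 3 is known only as a limit: the limit of > 16000 nM in this assay, at which 2 of the 4 values shown sit. Whether the change carries across cores cannot be said, since the step from compound 1 to compound 2 is unreadable, leaving a single readable instance, and because compound 2 is likewise known only as a limit: the limit of > 8000 nM in this assay, at which 1 of the 4 values shown sits.

The compounds shown leave open whether the stronger inhibition on the core of compound 3 needs the methoxy group or would also appear with plain phenylamino. They also leave open whether an open-chain amine such as diethylamino or a ring amine such as morpholin-4-yl would behave like piperidin-1-yl or like (3-methoxyphenyl)amino on either core.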